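The source may report more compounds than this note shows. Statements on the series, on what has been measured and on what is new or still open speak of the compounds shown alone.

In a functional assay on MCF7 cells (Homo sapiens) for cytotoxicity, read by CellTiter-Glo, with a stated time of 5 days (a higher number here means a weaker inhibitor, a lower number a stronger inhibitor), compound 1 `CC/C(=C(/c1ccc(/C=C/C(=O)O)cc1)c1ccc2[nH]ncc2c1)c1ccccc1` gives 6 nM, while compound 2 `CC/C(=C(/c1ccc(/C=C/C(=O)O)cc1)c1ccc2[nH]ncc2c1)c1cccc(C#N)c1` gives 100 nM, the higher of the two numbers. Compound 3 `CC/C(=C(/c1ccc(/C=C/C(=O)O)cc1)c1ccc2[nH]ncc2c1)c1ccc(C#N)cc1` has 4-cyanophenyl in place of 3-cyanophenyl on a double-bonded chain carbon bound to a double-bonded chain carbon and a saturated chain carbon. Among the compounds with values here, the only measured step, a 17-fold higher number from compound 1 to compound 2 (1.22 log units; beyond the scatter), is large and comes with cyano in place of hydrogen on an aromatic carbon. Within the data shown here, no measured step shows a swap between these two groups, so that step gives only a rough scale, and a smaller shift toward a lower number is expected in this assay. The estimated change is a 2.0-fold lower number from compound 2 to compound 3 (0.30 log units; within the scatter). For compound 3, the expected value is 50 nM, with an estimated range from 10 nM to 250 nM.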

Compound 3, half-maximal inhibitory concentration: 47 nM
Compound 3: the middle estimate sits 1.1-fold (0.03 log units) above what was measured; the range from low to high includes it.
By their numbers in this assay, from the lowest: compound 1; then compound 3; then compound 2.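

Where the nitrile sits on the ring matters: in this assay, swapping 3-cyanophenyl for 4-cyanophenyl gives a 2.1-fold lower number from compound 2 to compound 3 (0.33 log units; beyond the scatter) even though the atoms are the same. The nitrile is still not tolerated as well as hydrogen in this new arrangement, with a 7.8-fold higher number from compound 1 to compound 3 (0.89 log units; beyond the scatter) in the same assay. Nothing shown explains why the two arrangements differ.

As far as these compounds go, whether any substituent on this ring can match or improve on the unsubstituted phenyl of compound 1 stays open. A fluorine, a methoxy group or an amine in the same place could answer that.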